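Swapping the thioether substituent on the shared core

This account rests on a few compounds, and the source may have more. Where it says the series, first, only, none or still open, it means among the compounds named here.

The series rests on a shared core, seen in compound 1 `Cn1ncc2c(=O)n(-c3ccccc3)c(SC(C)(C)c3ccccc3)nc21`. Measured in an assay on isolated protein for inhibition of Retinaldehyde dehydrogenase 3 (Homo sapiens) (on this read-out lower numbers stand for stronger inhibition and higher numbers for weaker inhibition), compound 1 gives 1390 nM, which places it second highest among the three numbers recorded. Compound 2 `CC(Sc1nc2c(cnn2C)c(=O)n1-c1ccc(CO)cc1)c1ccccc1` gives 1000 nM in this assay, and compound 3 `Cn1ncc2c(=O)n(-c3ccccc3)c(CCc3cccc(F)c3)nc21` gives 2500 nM. Both of these sit within the usual scatter of compound 1, so no order can be read among the three.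

Compound 4 `CC(Sc1nc2c(cnn2C)c(=O)n1-c1ccccc1)c1cncnc1` has not yet been measured. It differs from compound 1 in one place: 1-(pyrimidin-5-yl)ethyl in place of 1-methyl-1-phenylethyl on a sulfur. The thioether is kept, while the substituent on the sulfur loses one carbon and gains two ring nitrogens.

With no measured step of this kind in the data, the change from compound 1 is expected to move the number little, and the step of a 1.1-fold higher number from compound 1 to compound 4 (0.03 log units; within the scatter) is estimated to lie within the scatter. Compound 4 is therefore expected to give about 1500 nM in this assay, within a range of 500 nM to 4500 nM.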

Compound 4, half-maximal inhibitory concentration: 100 nM
The estimate for compound 4 lay 15-fold (1.18 log units) above the measured number, and the stated range ends above it.
By their numbers in this assay, from the lowest: compound 4; then compounds 2, 1 and 3 (each within the scatter of the next, the first and the last beyond it).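

In this assay, for the compounds shown here, the group on the sulfur turns out to be a place where the number can move far, with a 14-fold lower number from compound 1 to compound 4 (1.14 log units; beyond the scatter), a step larger than any gap to compound 1 among the earlier compounds. This one step carries two changes at once: the six-membered aromatic ring of carbon only gives way to one with 2 hetero atoms, and 1-methyl-1-phenylethyl loses a methyl to become an ethyl-based group, so the compounds shown cannot assign the drop to either change alone. Nothing measured here offers an explanation for this result.

Going by these compounds, whether the ring nitrogens, the missing methyl or both carry the step therefore stays open. Also open, on these data alone, is what a 1-(pyridin-3-yl)ethyl group, with one ring nitrogen, or a carboxylic acid on this substituent would give.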